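This account rests on a few compounds, and the source may have more. Where it says the series, first, only, none or still open, it means among the compounds named here.

Measured compounds in this study:

Compound 1 `O=C(O)CNc1cccc(CNc2cc(C(F)(F)F)cc3[nH]ncc23)c1`; in an assay for inhibition of Indoleamine 2,3-dioxygenase 1 (Homo sapiens), with stated times of 10 min and 60 min (a higher number here means a weaker inhibitor, a lower number a stronger inhibitor), compound 1 gives > 100000 nM, which is a limit of the assay and not a number.

Compound 2 `O=[N+]([O-])c1ccc(Cl)cc1CNc1cc(C(F)(F)F)cc2[nH]ncc12`; in this assay compound 2 gives 37700 nM.

Compound 3 `O=[N+]([O-])c1cc(Br)c(F)cc1CNc1cc(C(F)(F)F)cc2[nH]ncc12`; in this assay compound 3 gives > 100000 nM, also a limit of the assay.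

Compound 1 thus stands at the edge of what this assay can report, sharing (the limit of > 100000 nM in this assay, at which 2 of the 3 values shown sit), and only compound 2 returns a number at all. Compound 4 `FC(F)(F)c1cc(NCc2cccc(Br)c2)c2cn[nH]c2c1` differs from compound 1 in one place: bromo in place of (carboxymethyl)amino on an aromatic carbon. No measured pair here shares that change, so its effect is inferred, not shown. The step is expected to be an at least 1.6-fold lower number from compound 1 to compound 4 (0.22 log units; that floor lies within the scatter), small and not clearly beyond the scatter. Compound 4 is therefore estimated at 60000 nM in this assay, within 15000 nM to 250000 nM.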

Compound 4, half-maximal inhibitory concentration: > 100000 nM
Compound 4 gave a limit, no number; the forecaster's own chance of this, stated with the estimate: 55%; at least 1.6-fold (0.22 log units) between middle value and limit.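

Among these compounds, compound 1 and compound 4 both end at a limit of the assay, not at a number, so no step between them can be read: the limit of > 100000 nM in this assay, at which 3 of the 4 values shown sit. The compounds shown leave open whether bromo in place of (carboxymethyl)amino on an aromatic carbon changes inhibition in this assay at all.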